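Swapping the amide aryl group on an acetamido core

The source may report more compounds than this note shows. Statements on the series, on what has been measured and on what is new or still open speak of the compounds shown alone.

Three compounds share a biaryl scaffold bearing an anilide and differ in the group on the amide carbonyl and in the substituent on the core. Compound 1 `Nc1cccc2c(-c3cccc(NC(=O)c4ccc5c(c4)OCCO5)c3)ccnc12` gives 45 nM in a functional assay on SK-MEL-5 cells (Homo sapiens) for antiproliferative activity, read by sulforhodamine B assay, with a stated time of 48 h; on this read-out higher numbers stand for weaker inhibition and lower numbers for stronger inhibition. Compound 2 `COc1ccc(C(=O)Nc2cccc(-c3ccnc4c(NC(C)=O)cccc34)c2)cc1OC` gives 480 nM, and compound 3 `CC(=O)Nc1cccc2c(-c3cccc(NC(=O)c4ccc(Cl)c(C(F)(F)F)c4)c3)ccnc12` gives 1700 nM, the highest of the three numbers, with compound 2 nearest and compound 1 furthest. For the measured compounds named here, the one measured step that touches the amide aryl group, a 3.5-fold higher number from compound 2 to compound 3 (0.55 log units; beyond the scatter), runs toward the weaker end. Compound 4 `CC(=O)Nc1cccc2c(-c3cccc(NC(=O)c4ccc5c(c4)OCCO5)c3)ccnc12` is compound 3 with 2,3-dihydro-1,4-benzodioxin-6-yl in place of 4-chloro-3-(trifluoromethyl)phenyl on a carbonyl carbon. Going by the values given here, this change removes the very group that the step from compound 2 to compound 3 brought in, and installs the aryl group that compound 1 carries, so a move back toward lower numbers is expected, of about the size seen in that step, though no measured step covers exactly this pair. Compound 4 is therefore expected to reach 400 nM, a step of a 4.3-fold lower number from compound 3 to compound 4 (0.63 log units; beyond the scatter), within a range of 120 nM to 1300 nM.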

Compound 4, half-maximal inhibitory concentration: 56 nM
For compound 4 the middle estimate is 7.1-fold (0.85 log units) above the measured one, and the stated range ends above it.
By their numbers in this assay, from the lowest: compounds 1 and 4 (each within the scatter of the next); then compound 2; then compound 3.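

In this assay the 2,3-dihydro-1,4-benzodioxin-6-yl group on the carbonyl carbon proves far better than 4-chloro-3-(trifluoromethyl)phenyl (a 30-fold lower number from compound 3 to compound 4 (1.48 log units; beyond the scatter)), a much larger step than any seen earlier at this position, and it also improves on 3,4-dimethoxyphenyl (an 8.6-fold lower number from compound 2 to compound 4 (0.93 log units; beyond the scatter)). With acetyl on the core nitrogen, the three aryl groups therefore fall into a clear order, with 2,3-dihydro-1,4-benzodioxin-6-yl giving the lowest number and 4-chloro-3-(trifluoromethyl)phenyl the highest. With 2,3-dihydro-1,4-benzodioxin-6-yl in place, acetyl in place of hydrogen on the nitrogen leaves no readable difference (a 1.2-fold higher number from compound 1 to compound 4 (0.09 log units; within the scatter)).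

From the compounds shown here alone, whether that holds with the other aryl groups stays open, as does how an amine or a carboxylic acid on the aryl group, or a longer acyl chain on the core nitrogen, would read. Nothing at hand accounts for the differences between these aryl groups.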